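The source may hold more compounds than are shown below. What is called first, only, known or untested is meant among the compounds shown, and "the series" means these compounds.

Measured compounds:
- Compound 1, `O=C(NCc1cn(Cc2ccc(F)cc2)nn1)c1cn(-c2ccccc2)nc1-c1ccc(F)cc1`: 1200 nM
- Compound 2, `COc1cc(Cn2cc(CNC(=O)c3cn(-c4ccccc4)nc3-c3ccc(F)cc3)nn2)cc(OC)c1`: 360 nM
- Compound 3, `COc1ccc(-c2nn(-c3ccccc3)cc2C(=O)NCc2cn(Cc3ccc(F)cc3)nn2)cc1`: 500 nM

These three share one core and were tested in a functional assay on HeLa cells (Homo sapiens) for antiproliferative activity, read by sulforhodamine B assay, with a stated time of 48 h; on this read-out lower numbers stand for stronger inhibition of growth and higher numbers for weaker inhibition of growth. Compound 3 holds the second highest number of the three: against compound 2 the gap is within the scatter, while compound 1 sits clearly higher, as a 2.4-fold lower number from compound 1 to compound 3 (0.38 log units; beyond the scatter) shows.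

Compound 4, `COc1ccc(-c2nn(-c3ccccc3)cc2C(=O)NCc2cn(Cc3cc(OC)cc(OC)c3)nn2)cc1`, has not yet been measured. It differs from compound 3 by 3,5-dimethoxyphenyl in place of 4-fluorophenyl on a saturated chain carbon bound to an aromatic nitrogen. The same change has already been seen once, going from compound 1 to compound 2, where a 3.3-fold lower number from compound 1 to compound 2 (0.52 log units; beyond the scatter) was recorded in this assay. Among the measured compounds shown here, that single step is the only guide here, and it was modest but beyond the scatter. A step of similar size and direction is therefore expected, a 2.9-fold lower number from compound 3 to compound 4 (0.47 log units; beyond the scatter). Compound 4 is accordingly estimated at 170 nM, with a plausible range from 70 nM to 400 nM.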

Compound 4, concentration for 50% growth inhibition: 12400 nM
Estimate against measurement, compound 4: 73-fold (1.86 log units) below, and the stated range ends below it.
By their numbers in this assay, from the lowest: compounds 2 and 3 (each within the scatter of the next); then compound 1; then compound 4.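

Swapping 4-fluorobenzyl for 3,5-dimethoxybenzyl has no fixed effect in this assay: when methoxy replaces fluoro on an aromatic carbon of the shared core, the swap gives a 25-fold higher number from compound 3 to compound 4 (1.39 log units; beyond the scatter), opposite in direction to the earlier step. Read the other way, methoxy in place of fluoro gives a 34-fold higher number from compound 2 to compound 4 (1.54 log units; beyond the scatter) when 3,5-dimethoxybenzyl is present. The two changes therefore do not simply add up, and the effect of each depends on the other: the same change on two cores in this assay, a 3.3-fold lower number (0.52 log units; beyond the scatter) from compound 1 to compound 2 and a 25-fold higher number (1.39 log units; beyond the scatter) from compound 3 to compound 4, 83-fold (1.92 log units) apart, beyond the scatter of two such steps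

From the compounds shown here alone, it remains open how far this dependence extends to other groups. An unsubstituted benzyl or a hydroxybenzyl at this place could follow either trend.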